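The compounds below may be only part of what the source reports. "The series", "measured", "known", "first", "only" and "open" are said of these compounds alone.

Compound 1 `Clc1cccc(Nc2ncnc3ccc(NCc4ncc5ccccc5n4)cc23)c1`: 1710 nM
Compound 2 `Clc1cccc(Nc2ncnc3ccc(NCc4cccs4)cc23)c1`: 2080 nM

Both numbers come from a functional assay on A549 cells (Homo sapiens) for antiproliferative activity, read by MTT assay, with a stated time of 48 h; a lower number here means a stronger inhibitor, a higher number a weaker inhibitor. Among the compounds with values here, compound 2 holds the higher of the two, but its only neighbour is compound 1, and the difference between the pair is a 1.2-fold higher number from compound 1 to compound 2 (0.09 log units; within the scatter), so the two compounds cannot be told apart on these numbers.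

Compound 3 `Clc1cccc(Nc2ncnc3ccc(NCc4c[nH]c5ccccc45)cc23)c1` is reached from compound 2 by a single exchange: 1H-indol-3-yl in place of thiophen-2-yl on a saturated chain carbon bound to a nitrogen on an aromatic ring. The shared core and the rest of the molecule are untouched. Within the data shown here, the one measured step that speaks to this change is the swap at the very same position, a 1.2-fold higher number from compound 1 to compound 2 (0.09 log units; within the scatter), which stayed within the scatter. On that basis no step beyond the scatter is expected in this assay, so the estimated change is a 1.2-fold lower number from compound 2 to compound 3 (0.06 log units; within the scatter). Compound 3 is therefore expected to give about 1800 nM, with a likely range from 700 nM to 4500 nM.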

Compound 3, half-maximal inhibitory concentration: 2330 nM
Estimate against measurement, compound 3: 1.3-fold (0.11 log units) below, and the stated range covers the measured number.
By their numbers in this assay, from the lowest: compounds 1, 2 and 3 (each within the scatter of the next).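

In this assay both a 1.1-fold higher number from compound 2 to compound 3 (0.05 log units; within the scatter) and a 1.4-fold higher number from compound 1 to compound 3 (0.13 log units; within the scatter) stay within the scatter, so 1H-indol-3-yl cannot be told apart from thiophen-2-yl or quinazolin-2-yl at this position. Compared with thiophen-2-yl, the entering group brings more heavy atoms, a second ring and a hydrogen-bond donor, yet the number on this saturated chain carbon bound to a nitrogen on an aromatic ring does not move beyond the scatter. Nothing available explains why these exchanges leave the number so little changed.

All three groups shown are aromatic rings. On these data alone, whether an amine, a carboxylic acid or a simple alkyl chain in the same place would give a step beyond the scatter remains open.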